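The source may report more compounds than this note shows. Statements on the series, on what has been measured and on what is new or still open speak of the compounds shown alone.

Of the compounds shown here, three built on one shared core have been measured in an ADME assay on NIH3T3 cells (Mus musculus) for cytotoxicity, read by MTT assay, with a stated time of 24 h; on this read-out higher numbers stand for weaker inhibition and lower numbers for stronger inhibition. Compound 1 `Cc1ccc2oc(-c3ccc(NC(=O)CN4CCN(CCN(C)C)CC4)cc3)nc2c1` gives 28900 nM. Compound 2 `Cc1ccc2oc(-c3ccc(NC(=O)CN4CCN(CCCN(C)C)CC4)cc3)nc2c1` gives 26400 nM, the second highest of the three numbers, nearest to compound 1 and furthest from compound 3. Compound 3 `CN(C)CCCN1CCN(CC(=O)Nc2ccc(-c3nc4ccccc4o3)cc2)CC1` gives 16700 nM. Two steps connect these compounds: a 1.1-fold lower number from compound 1 to compound 2 (0.04 log units; within the scatter), and a 1.6-fold lower number from compound 2 to compound 3 (0.20 log units; within the scatter); neither rises above the scatter of repeated measurements.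

Compound 4 `Cc1ccc2oc(-c3ccc(NC(=O)CN4CCN(CCCN(C)C)CC4)c(C)c3)nc2c1` has not yet been measured. It differs from compound 2 in one place: methyl in place of hydrogen on an aromatic carbon, on an aromatic carbon of a six-membered aromatic ring of carbon only, ortho to a large group and meta to the 5-methyl-1,3-benzoxazol-2-yl group. Of the measured steps, the one that bears on this change is a 1.6-fold lower number from compound 2 to compound 3 (0.20 log units; within the scatter), which also concerned a methyl on an aromatic carbon; the other, a 1.1-fold lower number from compound 1 to compound 2 (0.04 log units; within the scatter), concerned the chain and says nothing about an aromatic methyl. Because a 1.6-fold lower number from compound 2 to compound 3 (0.20 log units; within the scatter) stayed within the scatter, the step from compound 2 to compound 4 is expected to be small, with no firm direction, and the estimated step is a 1.0-fold lower number from compound 2 to compound 4 (0.01 log units; within the scatter). Compound 4 is therefore estimated at 26000 nM, with a range from 11000 nM to 60000 nM.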

Compound 4, half-maximal inhibitory concentration: 13200 nM
Compound 4: the middle estimate sits 2.0-fold (0.29 log units) above what was measured; the measured number falls inside the stated range.
By their numbers in this assay, from the lowest: compounds 4, 3, 2 and 1 (each within the scatter of the next, the first and the last beyond it).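

In this assay, among these compounds, a methyl on this aromatic carbon, ortho to a large group and meta to a 5-methyl-1,3-benzoxazol-2-yl group, gives the first reading for this position (a 2.0-fold lower number from compound 2 to compound 4 (0.30 log units; within the scatter)), and that step lies within the scatter. Among the compounds shown here, the only earlier aromatic change concerned a methyl on a different aromatic carbon (a 1.6-fold lower number from compound 2 to compound 3 (0.20 log units; within the scatter)), so the series now holds a methyl change at two separate aromatic positions, and at neither does the step rise above the scatter of repeated measurements. Nothing available on the compounds accounts for the size of this step or ties it to any property of the methyl.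

The compounds shown leave open whether a chlorine, a methoxy or an ethyl on this same carbon would stay within the scatter as the methyl does, or would give a step beyond it. They also leave open whether this methyl would give a step of similar size on the chain of compound 1, or on compound 3, which lacks the other aromatic methyl.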